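Series notes: swapping the N-aryl ring of compound 1

The compounds below may be only part of what the source reports. "The series", "measured", "known", "first", "only" and "open" are said of these compounds alone.

Compound 1 `Cc1ccccc1-c1nn(-c2ccc(C(F)(F)F)cc2)cc1CNCCN1CCN(C)CC1` is the reference point of this set. Within the data shown here, in an ADME assay on Huh-7 cells (Homo sapiens) for cytotoxicity (on this read-out higher numbers stand for lower toxicity in this test and lower numbers for higher toxicity in this test), compound 1 gives 11000 nM, the highest of the three numbers known. Compound 2 `CN1CCN(CCNCc2cn(-c3ccc(C(F)(F)F)cc3)nc2-c2ccc(C(F)(F)F)cc2)CC1` gives 1500 nM and compound 3 `CN1CCN(CCNCc2cn(-c3ccc(C(F)(F)F)cc3)nc2-c2ccc(OC(F)(F)F)cc2)CC1` gives 3000 nM; the change from compound 1 to compound 2 is a 7.3-fold lower number from compound 1 to compound 2 (0.87 log units; beyond the scatter) and that from compound 1 to compound 3 is a 3.7-fold lower number from compound 1 to compound 3 (0.56 log units; beyond the scatter), while between compound 2 and compound 3 the difference is a 2.0-fold higher number from compound 2 to compound 3 (0.30 log units; within the scatter).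

Compound 4 `Cc1ccc(-n2cc(CNCCN3CCN(C)CC3)c(-c3ccccc3C)n2)c(C)c1` is not yet measured. It differs from compound 1 as follows: 2,4-dimethylphenyl in place of 4-(trifluoromethyl)phenyl on an aromatic nitrogen. Among the measured compounds shown here, both measured steps concern the group on an aromatic carbon, not the group on the aromatic nitrogen; no measured step touches the position changed here. The two known steps show that the group on the aromatic carbon can shift the number modestly, so the position on the aromatic nitrogen may also matter, but its direction is unsupported by any pair in hand.

The expected number for compound 4 is therefore close to that of compound 1, with a step of no change at the digits printed from compound 1 to compound 4 (within the scatter) that is not expected to exceed the scatter, though the uncertainty is wide. The estimate for compound 4 in this assay is 11000 nM, within a range from 3500 nM to 35000 nM.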

Compound 4, half-maximal cytotoxic concentration: > 20000 nM
Compound 4 ended at the assay's limit; the forecaster's own chance of this, stated with the estimate: 10%; at least 1.8-fold (0.25 log units) between middle value and limit.
By their numbers in this assay, from the lowest: compounds 2 and 3 (each within the scatter of the next); then compound 1. At a limit, above all of these: compound 4.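

In this assay compound 4 gives > 20000 nM, which is a limit and not a number: the limit of > 20000 nM in this assay, at which 1 of the 4 values shown sits. Among these compounds, this is the first reading at the aromatic nitrogen, where 2,4-dimethylphenyl in place of 4-(trifluoromethyl)phenyl gives an at least 1.8-fold higher number from compound 1 to compound 4 (0.25 log units; that floor lies within the scatter), so the floor of the step alone does not establish a rise, and its true size is unknown. What the result adds is that this change at the nitrogen does not bring the lower numbers seen for the changes on the aromatic carbon, a 7.3-fold lower number from compound 1 to compound 2 (0.87 log units; beyond the scatter) and a 3.7-fold lower number from compound 1 to compound 3 (0.56 log units; beyond the scatter); the 2-methylphenyl group stays in place throughout the new step, so this reading belongs to the nitrogen position alone.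

The compounds shown leave open how a plain phenyl or a 4-chlorophenyl on the aromatic nitrogen would read, and whether either methyl group of the 2,4-dimethylphenyl alone would give the same result. Also open, from the compounds shown here alone, is whether 2,4-dimethylphenyl on the nitrogen would read the same way with the 4-(trifluoromethyl)phenyl of compound 2 on the aromatic carbon.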